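Ethyl ester variant of compound 1: an expectation

The compounds below may be only part of what the source reports. "The series", "measured", "known", "first", "only" and "open" are said of these compounds alone.

Measured so far:
compound 1, `CCCCCCCCCCCC(=O)N[C@H](CCC(=O)NC(CCCC(N)C(=O)O)C(=O)O)C(=O)O` — 0.027 nM
compound 2, `CCCCCCCCN(CCCCCCCC)[C@H](CCC(=O)NC(CCCC(N)C(=O)O)C(=O)O)C(=O)O` — 0.2 nM
compound 3, `CCCCCCCCCCCC(=O)N[C@H](CCC(=O)NC(CCCC(NC(=N)N)C(=O)O)C(=O)O)C(=O)O` — 0.622 nM

The three compounds were tested in a functional assay on HEK293 cells for agonist activity at Nucleotide-binding oligomerization domain-containing protein 1 (Homo sapiens), read by spectrophotometry; on this read-out higher numbers stand for an effect only at larger amounts of compound and lower numbers for an effect already at smaller amounts. Compound 1 stands at the lowest number of the three. Its nearest neighbour is compound 2, whose number is higher by a margin beyond the scatter, and the furthest is compound 3. Going by the values given here, the one single-point step among the measured compounds is a 23-fold higher number from compound 1 to compound 3 (1.36 log units; beyond the scatter), a large rise in the number.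

Compound 4, `CCCCCCCCCCCC(=O)N[C@H](CCC(=O)NC(CCCC(N)C(=O)O)C(=O)O)C(=O)OCC`, differs from compound 1 by ethyl in place of hydrogen on an oxygen next to a carbonyl group. Neither measured step touches this part of the molecule: the step from compound 1 to compound 3 concerns an amine nitrogen, and the gap between compound 1 and compound 2 lies at the amide of the shared core. Among the compounds with values here, there is therefore no measured step that bears directly on the change from compound 1 to compound 4, and no ground for expecting a large move in either direction. Compound 4 is expected to give a step of a 3.0-fold higher number from compound 1 to compound 4 (0.47 log units; beyond the scatter), with a somewhat higher number judged more likely than a lower one, within a wide range. For compound 4 the estimated value in this assay is 0.08 nM, expected to lie between 0.015 nM and 0.5 nM.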

Compound 4, half-maximal effective concentration: 0.069 nM
Estimate against measurement, compound 4: 1.2-fold (0.06 log units) above; low and high end bracket the measured number.
By their numbers in this assay, from the lowest: compound 1; then compound 4; then compound 2; then compound 3.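

In this assay, going by these compounds alone, replacing the hydrogen on this oxygen with ethyl gives a 2.6-fold higher number from compound 1 to compound 4 (0.41 log units; beyond the scatter), the first reading at this position. Turning carboxy into ethoxycarbonyl therefore moves the number by a modest step beyond the scatter, and compound 4 keeps a low number of 0.069 nM; the earlier step on the amine nitrogen, a 23-fold higher number from compound 1 to compound 3 (1.36 log units; beyond the scatter), is classed as large. Nothing available explains why this change raises the number.

The compounds shown do not tell whether the rise follows from the loss of the hydrogen or from the size of the ethyl group, a question that methyl or a longer chain such as butyl on this oxygen, or an amine-derived amide in place of the ester, would help to separate. They also leave open whether ethyl at this position would give a similar step on the dioctylamine of compound 2 or the guanidine of compound 3, and whether ethyl on either of the other two carboxylic acids would act as it does here.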